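Benzyloxy to phenethyl on the carbonyl carbon

The source may hold more compounds than are shown below. What is called first, only, known or untested is meant among the compounds shown, and "the series" means these compounds.

In an ADME assay on MT2 cells (Homo sapiens) for cytotoxicity, read by XTT assay, with a stated time of 4 days (on this read-out higher numbers stand for lower toxicity in this test and lower numbers for higher toxicity in this test), compound 1 `Cc1ccc(-c2c3c(nc(C)c2[C@H](OC(C)(C)C)C(=O)O)CCN(C(=O)OCc2ccccc2)C3)cc1` gives > 40000 nM as a limit, not a number. Compound 2 `Cc1nc2c(c(-c3cc(F)c4c(c3C)CCCO4)c1[C@H](OC(C)(C)C)C(=O)O)CN(CCCc1ccc(F)cc1)CC2` likewise gives > 40000 nM as a limit. Compound 1 therefore stands with the limit of > 40000 nM in this assay, at which 2 of the 2 values shown sit, and no numerical value yet. Compound 3 `Cc1ccc(-c2c3c(nc(C)c2[C@H](OC(C)(C)C)C(=O)O)CCN(C(=O)CCc2ccccc2)C3)cc1` has phenethyl in place of benzyloxy on a carbonyl carbon, a change counted as phenethyl in place of benzyloxy on a carbonyl carbon in full. Among the measured compounds shown here, no measured step is available, so no change beyond the scatter is expected in this assay for this swap. The estimated a number no higher from compound 1 to compound 3 (the limit leaves the size open) is expected to stay within the scatter. For compound 3 the estimated value is 40000 nM with an expected range from 20000 nM to 80000 nM in this assay.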

Compound 3, half-maximal cytotoxic concentration: > 40000 nM
Compound 3 ended at the assay's limit; the forecaster's own chance of this, stated with the estimate: 85%; the middle value lies on the limit itself.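

Compound 1 and compound 3 both end at a limit, not a number, so no step can be read for phenethyl in place of benzyloxy: the limit of > 40000 nM in this assay, at which 3 of the 3 values shown sit. The compounds shown leave open where any of them would give a numerical value in this assay.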